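Ring amide nitrogen: chlorophenyl to dimethylphenyl

The source may report more compounds than this note shows. Statements on the series, on what has been measured and on what is new or still open speak of the compounds shown alone.

Measured so far in a functional assay, read by spectrophotometry, with a stated time of 2 h, tested at 1 mg/mL; a higher number here means a stronger effect of the compound at the concentration tested, a lower number a weaker effect:

compound 1 `CC(C)[C@@H]1CC[C@@H](C)C[C@@]12N(C)C(=O)[C@@H]1[C@H]3C(=O)N(C)C(=O)[C@H]3ON12`: 47.7%
compound 2 `CC(C)[C@@H]1CC[C@@H](C)C[C@@]12N(C)C(=O)[C@@H]1[C@H]3C(=O)N(c4ccc(Cl)cc4)C(=O)[C@H]3ON12`: 53.7%

Going by the values given here, compound 2 and compound 1 sit within the scatter of each other; the only step, a number 6 percentage points higher from compound 1 to compound 2 (within the scatter), changes the same nitrogen from methyl to 4-chlorophenyl and does not move the read-out beyond the usual spread. Nothing further is known about this series in this assay.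

Compound 3 `Cc1ccc(N2C(=O)[C@H]3[C@H](ON4[C@@H]3C(=O)N(C)[C@@]43C[C@H](C)CC[C@H]3C(C)C)C2=O)c(C)c1` is the next member. Its change from compound 2 is 2,4-dimethylphenyl in place of 4-chlorophenyl on an amide-type nitrogen in a ring. Among the compounds with values here, no measured step exchanges one aryl group for another at this position, so the only guide is the step from compound 1 to compound 2, which left the read-out essentially unchanged when methyl gave way to 4-chlorophenyl. On that basis the expectation for this assay is a step from compound 2 to compound 3 of no size beyond the scatter, estimated as a number 2.7 percentage points lower from compound 2 to compound 3 (within the scatter). Compound 3 is therefore expected to give about 51% in this assay, with a range from 36% to 66%.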

Compound 3, a percentage reported as activity, at one concentration (the size of the read-out at that concentration, not a potency): 53.1%
Compound 3: the middle estimate sits 2.1 percentage points below what was measured, within the range that was stated.
By their numbers in this assay, from the lowest: compounds 1, 3 and 2 (each within the scatter of the next).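

In this assay, going by these compounds alone, the exchange of one aryl group for another on the amide-type nitrogen gives a number 0.6 percentage points lower from compound 2 to compound 3 (within the scatter), the first reading of an aryl-for-aryl change at this position: 2,4-dimethylphenyl, with 8 heavy atoms and no chlorine, cannot be told apart from 4-chlorophenyl, with 7 heavy atoms including one chlorine. Against the methyl group of compound 1, the same aryl group gives a number 5.4 percentage points higher from compound 1 to compound 3 (within the scatter), so two differently substituted aryl groups now each sit within the scatter of methyl, and none of the three groups shown on this nitrogen separates from the others in this assay. No supporting data bear on the interpretation of these results.

The compounds shown leave open whether any group on this nitrogen can move the read-out beyond the scatter, for example an amine on a longer chain or a carboxylic acid on a benzyl group. They also leave open whether these three compounds would separate at other concentrations, since this assay gives the size of the read-out at one concentration and not a potency.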